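The compounds below may be only part of what the source reports. "The series", "measured", "known", "first", "only" and "open" are said of these compounds alone.

Series notes, compound 2 and its chloro analogue.

The shared core is a benzenesulfonamide linked through a diacylhydrazide to a second aryl ring; compound 1 `NS(=O)(=O)c1ccc(C(=O)NNC(=O)c2ccc(Cl)c(Cl)c2)cc1` carries 3,4-dichlorophenyl there and compound 2 `NS(=O)(=O)c1ccc(C(=O)NNC(=O)c2ccc(F)cc2)cc1` carries 4-fluorophenyl. In an assay on cells for inhibition of Amine oxidase [flavin-containing] A (Homo sapiens), read by fluorescence and spectrophotometry, using microsomes, with a stated time of 20 min (a higher number here means a weaker inhibitor, a lower number a stronger inhibitor), compound 1 gives 13600 nM and compound 2 gives 39600 nM. Within the data shown here, compound 2 thus stands at the highest of the two numbers in this assay, with compound 1 at the nearer and lower value; the one measured step, a 2.9-fold higher number from compound 1 to compound 2 (0.46 log units; beyond the scatter), is modest but beyond the scatter.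

The next compound, compound 3 `NS(=O)(=O)c1ccc(C(=O)NNC(=O)c2ccc(Cl)cc2)cc1`, differs from compound 2 by chloro in place of fluoro on an aromatic carbon. Among the measured compounds shown here, the single step on record, from compound 1 to compound 2, replaces the whole dichlorophenyl by fluorophenyl and so brackets the move to chlorophenyl only in part. Taking compound 2 as the start, a lower number is expected for compound 3 in this assay, a step of about a 1.8-fold lower number from compound 2 to compound 3 (0.26 log units; within the scatter), which is expected to fall short of the measured step of a 2.9-fold higher number from compound 1 to compound 2 (0.46 log units; beyond the scatter). Compound 3 is estimated at 22000 nM, with a likely range from 11000 nM to 45000 nM.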

Compound 3, half-maximal inhibitory concentration: 55900 nM
Compound 3: middle estimate off by 2.5-fold (0.40 log units), on the low side; the whole stated range lies below it.
By their numbers in this assay, from the lowest: compound 1; then compounds 2 and 3 (each within the scatter of the next).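

At the aromatic carbon para to a large group, chloro in place of fluoro gives a 1.4-fold higher number from compound 2 to compound 3 (0.15 log units; within the scatter), so in this assay the 4-fluorophenyl and 4-chlorophenyl compounds cannot be told apart, and the identity of this single halogen shows no measurable effect on the read-out. The step that does clear the scatter is the loss of the second chloro of compound 1: hydrogen in place of chloro on an aromatic carbon gives a 4.1-fold higher number from compound 1 to compound 3 (0.61 log units; beyond the scatter), a modest step, and it places the 3,4-dichlorophenyl compound apart from both compounds with one halogen, with neither compound 2 nor compound 3 going against this within the three compounds shown. Nothing at hand gives a reason for this difference between the ring patterns.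

Open, from the compounds shown here alone, is whether a methoxy group or an amine at the carbon now holding the halogen would stay level with compound 2 and compound 3 or depart from them. Also open, going by these compounds, is whether a methyl group in place of the second chloro of compound 1 would keep the value of compound 1 or fall back towards that of compound 3.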